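Benzylthio series: cytotoxicity limits and a chloro analogue

The compounds below may be only part of what the source reports. "The series", "measured", "known", "first", "only" and "open" are said of these compounds alone.

compound 1 `O=c1[nH]c(SCc2ccccc2)nc2ccccc12` — > 64000 nM
compound 2 `O=c1[nH]c(SCc2ccc(-c3ccccc3)cc2)nc2ccccc12` — > 64000 nM

In an ADME assay on MRC5 cells (Homo sapiens) for cytotoxicity, read by neutral red uptake (on this read-out higher numbers stand for lower toxicity in this test and lower numbers for higher toxicity in this test), compound 1 reaches only a limit, > 64000 nM. For compound 2 the value > 64000 nM is likewise a limit. The step that the two limits leave unreadable from compound 1 to compound 2 therefore cannot be read, since both values sit at the limit of > 64000 nM in this assay, at which 2 of the 2 values shown sit. Compound 3 `O=c1[nH]c(SCc2ccccc2Cl)nc2ccccc12` carries the change (chloro in place of hydrogen on an aromatic carbon). Going by the values given here, no measured step bears on this change, and with compound 1 known only as a limit, no direction can be expected beyond the scatter in this assay. Compound 3 is therefore expected at 80000 nM (range 30000 nM to 200000 nM), most likely again reported as a limit. The implied step that the limit leaves unreadable from compound 1 to compound 3 is thus expected to be small.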

Compound 3, half-maximal cytotoxic concentration: > 65000 nM
Compound 3 gave a limit, no number; the forecaster's own chance of this, stated with the estimate: 80%; the middle value is on the limit's open side.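

Compound 1 and compound 3 are both known only as limits in this assay, so the step between them cannot be read. The compounds shown leave open whether chloro or phenyl in place of hydrogen changes cytotoxicity.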